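An Acetyl in Place of Hydrogen on Compound 1

This account rests on a few compounds, and the source may have more. Where it says the series, first, only, none or still open, it means among the compounds named here.

Compound 1 `O=c1cc(I)n([C@@H]2O[C@H](CO)[C@@H](O)[C@H]2O)c(=O)[nH]1` gives 15300 nM in a functional assay on ML1 cells (Homo sapiens) for antiproliferative activity, read by WST assay, with a stated time of 3 days; a higher number here means a weaker inhibitor, a lower number a stronger inhibitor.
Compound 2 `[N-]=[N+]=Nc1cc(=O)[nH]c(=O)n1[C@@H]1O[C@H](CO)[C@@H](O)[C@H]1O` gives in this assay only a limit of the assay, > 50000 nM.
Compound 3 `O=c1[nH]c(=O)n([C@@H]2O[C@H](CO)[C@@H](O)[C@H]2O)c(I)c1F` gives in this assay likewise only a limit of the assay, > 50000 nM.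

Compound 1 is the only one of the three with a measured number; the other two sit at the limit of > 50000 nM in this assay, at which 2 of the 3 values shown sit. Putting azido in place of iodo on an aromatic carbon gives an at least 3.2-fold higher number from compound 1 to compound 2 (0.51 log units; beyond the scatter), and putting fluoro in place of hydrogen on an aromatic carbon gives an at least 3.2-fold higher number from compound 1 to compound 3 (0.51 log units; beyond the scatter). Both of these changes sit on the aromatic part of the shared core.

Compound 4 `CC(=O)OC[C@H]1O[C@@H](n2c(I)cc(=O)[nH]c2=O)[C@H](O)[C@@H]1O` differs from compound 1 at another place: acetyl in place of hydrogen on an oxygen on a saturated carbon. Neither measured step concerns an oxygen on a saturated carbon, so neither bears directly on this change; they show only that the two alterations tried on the aromatic carbons of compound 1 weaken it. With nothing in the data speaking to the acetyl, the expectation for compound 4 is a step of a 1.3-fold lower number from compound 1 to compound 4 (0.11 log units; within the scatter), staying within the scatter. Compound 4 is therefore estimated at 12000 nM in this assay, with a range from 3000 nM to 45000 nM.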

Compound 4, half-maximal inhibitory concentration: 15200 nM
Compound 4: middle estimate off by 1.3-fold (0.10 log units), on the low side, within the range that was stated.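

At this oxygen on a saturated carbon, acetyl in place of hydrogen gives a 1.0-fold lower number from compound 1 to compound 4 (0.00 log units; within the scatter) in this assay, so the two compounds cannot be told apart in this read-out. This shows that the shared core has a place that accepts an added group of this size with no measurable loss, whereas both changes on its aromatic carbons, in compound 2 and compound 3, ended at a limit of the assay rather than at a number. The data shown contain no measurement that explains why this hydroxymethyl to acetoxymethyl change makes so little difference when the aromatic changes do not.

On these data alone, whether this place would accept more than an acetyl stays open: a longer chain such as butyryl, a benzoyl group, or an amine in place of the hydroxy could each read differently. As far as these compounds go, how the other hydroxy groups of the shared core would respond to the same acetyl, and whether an acetyl at this oxygen would behave the same way on compound 2 or compound 3, also remains open.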